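This account rests on a few compounds, and the source may have more. Where it says the series, first, only, none or still open, it means among the compounds named here.

Measured so far in a functional assay, read by Griess assay, with a stated time of 150 min, tested at 75 ug/mL; on this read-out lower numbers stand for a weaker effect and higher numbers for a stronger effect at the one concentration tested:
compound 1 `O=S(=O)(CC1=NCCO1)C1C(c2ccc(Cl)cc2)=NN(c2ccccc2)C1c1ccc(Cl)cc1`, "not active" (no number reported)
compound 2 `O=S(=O)(CC1=NCCO1)c1n[nH]cc1-c1ccccc1`, 54.7%
compound 3 `COc1ccc(-c2noc(-c3ccc(C)cc3)c2S(=O)(=O)CC2=NCCO2)cc1`, 73%

Compound 3 holds the higher of the two numbers recorded; compound 2 is the nearest, lower by a gap beyond the scatter, and compound 1 is recorded without a number. Compound 4 `COc1ccc(-c2noc(-c3ccc(C)cc3)c2S(=O)(=O)CC2=NCCS2)cc1` differs from compound 3 in one place: a group of 5 heavy atoms (3 carbon, 1 nitrogen, 1 sulfur; one five-membered non-aromatic ring with 2 hetero atoms) in place of a group of 5 heavy atoms (3 carbon, 1 nitrogen, 1 oxygen; one five-membered non-aromatic ring with 2 hetero atoms), on a saturated chain carbon bound to a sulfonyl sulfur. Among the compounds with values here, no pair among the measured compounds has this change, so no measured step supports a direction. The change is expected to shift the value of compound 4 against compound 3 by a number 3 percentage points lower from compound 3 to compound 4 (within the scatter), no step beyond the scatter. For compound 4 the estimated value in this assay is 70%, with a range from 50% to 85%.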

Compound 4, a percentage reported as activity, at one concentration (the size of the read-out at that concentration, not a potency): "not active" (no number reported)
Compound 4: no number reported; no gap can be computed for the estimate.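

Within the data shown here, compound 4 is recorded in this assay as "not active" (no number reported), so no step from compound 3 can be read, and no supporting data bear on this result. On these data alone, how far the sulfur-containing ring lowers or keeps the effect of compound 3 stays open.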